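Swapping chloro for methyl on a triazole-linked aryl ring

This account rests on a few compounds, and the source may have more. Where it says the series, first, only, none or still open, it means among the compounds named here.

Of the compounds shown here, three sharing a central ring system have been tested in a functional assay on the whole organism (Cricetulus griseus) with Cricetinae gen. sp. as the target; on this read-out lower numbers stand for an effect already at smaller amounts and higher numbers for an effect only at larger amounts of compound. Compound 1 `Cc1cc(Cl)ccc1-c1n[nH]c(-c2ccccc2)n1` gives 0.14 mg/kg. Compound 2 `Cc1ccc(-c2n[nH]c(-c3ccccc3)n2)c(C)c1` gives 0.2 mg/kg in this assay. Compound 3 `COc1cccc(-c2n[nH]c(-c3cc(Cl)ccc3C)n2)c1` gives 0.35 mg/kg in this assay; its number is the highest of the three, and its gap to compound 1 lies beyond the scatter, while its gap to compound 2 does not.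

Compound 1 and compound 2 differ in one place: methyl in place of chloro on an aromatic carbon. That change gave a 1.4-fold higher number from compound 1 to compound 2 (0.15 log units; within the scatter), a shift too small to count as a real difference.

Compound 4 `COc1cccc(-c2n[nH]c(-c3cc(C)ccc3C)n2)c1` has not yet been measured. It is related to compound 3 in the same kind of way: methyl in place of chloro on an aromatic carbon. The surroundings are not identical, though. In the move from compound 1 to compound 2 the altered carbon is meta to a methyl group and para to a large group, whereas in the move from compound 3 to compound 4 it is meta to a large group and para to a methyl group. How the core of compound 3 differs from the core of compound 1 is not broken down here.

Placed beside the earlier step of a 1.4-fold higher number from compound 1 to compound 2 (0.15 log units; within the scatter), the expected step is a 1.3-fold higher number from compound 3 to compound 4 (0.11 log units; within the scatter), resting on the single measured pair. Compound 4 is therefore estimated at 0.45 mg/kg in this assay, with a likely range from 0.25 mg/kg to 0.8 mg/kg.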

Compound 4, dose for half-maximal effect: 2.5 mg/kg
Compound 4: middle estimate off by 5.6-fold (0.74 log units), on the low side; measured number outside the range, above it.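

In this assay, the same swap of chloro for methyl on an aromatic carbon gave a 7.1-fold higher number from compound 3 to compound 4 (0.85 log units; beyond the scatter), so a change that made no real difference on the core of compound 1 made a clear one on the core of compound 3. The effect of this swap therefore cannot be carried from one core to the other as a fixed step, as the two measured pairs disagree: the same change on two cores in this assay, a 1.4-fold higher number (0.15 log units; within the scatter) from compound 1 to compound 2 and a 7.1-fold higher number (0.85 log units; beyond the scatter) from compound 3 to compound 4, 5.0-fold (0.70 log units) apart, beyond the scatter of two such steps

Going by these compounds alone, this does not show why the two steps differ: with only two pairs, the part played by the rest of the core cannot be separated from the part played by the immediate surroundings of the altered carbon, and no property of chloro or methyl is measured here.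

On these data alone, only chloro and methyl can be compared at this carbon, so it remains open whether a fluoro group, a nitrile or a trifluoromethyl group there would give a number close to that of compound 3 or that of compound 4. Also open, as far as these compounds go, is whether the methoxy group carried by compound 3 and compound 4 is the feature of their core that makes this swap matter, or whether the same would hold with an ethoxy group or a hydroxyl group in its place.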